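The source may report more compounds than this note shows. Statements on the series, on what has been measured and on what is new or still open speak of the compounds shown alone.

Compound 1 `CCCCCCCCn1cc(/C=C/C(=O)c2ccc(NC(=O)CN3CCN(c4ccccc4OC)CC3)cc2)nn1` gives 21500 nM in a functional assay on SK-N-SH cells (Homo sapiens) for inhibition, read by MTT assay; on this read-out lower numbers stand for stronger inhibition and higher numbers for weaker inhibition.
Compound 2 `CCCCCCCCCCn1cc(/C=C/C(=O)c2ccc(NC(=O)CN3CCN(C(=O)OC(C)(C)C)CC3)cc2)nn1` gives 77800 nM in this assay.
Compound 3 `CCCCCCCCCCn1cc(/C=C/C(=O)c2ccc(NC(=O)CN3CCN(c4ccccc4F)CC3)cc2)nn1` gives 34400 nM in this assay.

Among these three numbers, compound 3 sits second highest. Its gap to compound 1 lies within the usual scatter of repeated measurements, while its gap to compound 2 lies beyond it, so only the difference from compound 2 counts as a real one.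

Compound 4 `CCCCCCCCCCn1cc(/C=C/C(=O)c2ccc(NC(=O)CN3CCN(c4ccccc4OC)CC3)cc2)nn1` is the next compound to be measured. It differs from compound 3 in one place: methoxy in place of fluoro on an aromatic carbon. Among the measured compounds shown here, the one measured step that touches this part of the molecule is a 2.3-fold lower number from compound 2 to compound 3 (0.35 log units; beyond the scatter), but that step exchanged a carbamate for an aryl group on the ring nitrogen, whereas here the aryl group stays and only its small substituent changes. For the measured compounds named here, compound 1 already carries the 2-methoxyphenyl group, yet also a shorter chain on the triazole, so no single step can be drawn from it; its value and that of compound 3 nevertheless lie within the scatter of each other. On this basis the step is expected to be small, a 1.3-fold lower number from compound 3 to compound 4 (0.12 log units; within the scatter), with no clear direction. Compound 4 is therefore estimated at 26000 nM in this assay, in a range from 12000 nM to 55000 nM.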

Compound 4, half-maximal inhibitory concentration: 87600 nM
Beside the measured number, compound 4's estimate is 3.4-fold (0.53 log units) below it; measured number outside the range, above it.
By their numbers in this assay, from the lowest: compounds 1 and 3 (each within the scatter of the next); then compounds 2 and 4 (each within the scatter of the next).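

In this assay the small group on the aryl ring turns out to matter: methoxy in place of fluoro, on an aromatic carbon ortho to a large group, gives a 2.5-fold higher number from compound 3 to compound 4 (0.41 log units; beyond the scatter) on the same decyl chain. The earlier gain from putting an aryl group on the ring nitrogen, a 2.3-fold lower number from compound 2 to compound 3 (0.35 log units; beyond the scatter) for 2-fluorophenyl, therefore does not extend to every aryl group, as 2-methoxyphenyl in place of tert-butoxycarbonyl gives only a 1.1-fold higher number from compound 2 to compound 4 (0.05 log units; within the scatter) and leaves those two compounds indistinguishable in this assay. Among the compounds shown here, the chain can now also be read on its own for the first time: with 2-methoxyphenyl kept, the ethyl extension gives a 4.1-fold higher number from compound 1 to compound 4 (0.61 log units; beyond the scatter), a single pair that shows the longer chain carrying the higher number but sets no general trend.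

Still open, as far as these compounds go, is whether a chloro or hydroxyl group at this place would behave like fluoro or like methoxy, and whether a dodecyl chain would continue the chain step. Nothing measured here on these compounds accounts for why either change has the size it does.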